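A Hydroxy for Chloro Swap on the Cyclopentenone Series

The compounds below may be only part of what the source reports. "The series", "measured", "known", "first", "only" and "open" are said of these compounds alone.

Three compounds of one shared core have been run in an ADME assay on KB cells (Homo sapiens) for cytotoxicity, read by MTT assay, with a stated time of 72 h; a lower number here means a stronger inhibitor, a higher number a weaker inhibitor. Compound 1 `COc1ccc(C2=C(c3cc(OC)c(OC)c(OC)c3)C(=O)C(OC(C)=O)C2)cc1F` gives 33 ug/mL. Compound 3 `COc1ccc(C2=C(c3cc(OC)c(OC)c(OC)c3)C(=O)C(OC(C)=O)C2)cc1Cl` gives 64 ug/mL. Compound 2 `COc1ccc(C2=C(c3cc(OC)c(OC)c(OC)c3)CC(O[SiH2]C(C)(C)C)C2=O)cc1[N+](=O)[O-]` reaches only a limit of the assay at > 100 ug/mL; it reports no number, so the limit of > 100 ug/mL in this assay, at which 1 of the 3 values shown sits, is all that is known of it. Between the two numbers, a 1.9-fold higher number from compound 1 to compound 3 (0.29 log units; within the scatter), so compound 3 and compound 1 sit together within the scatter of the assay, and compound 3 is the one nearer to the limit.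

Compound 4 `COc1ccc(C2=C(c3cc(OC)c(OC)c(OC)c3)C(=O)C(OC(C)=O)C2)cc1O` differs from compound 3 in one place: hydroxy in place of chloro on an aromatic carbon. Among the measured compounds shown here, no measured step touches a hydroxy group, and the one measured step concerns only a change of halogen. The expected step in this assay, a 1.6-fold lower number from compound 3 to compound 4 (0.20 log units; within the scatter), is therefore expected to be modest, because a 1.9-fold higher number from compound 1 to compound 3 (0.29 log units; within the scatter) itself lies within the scatter. Compound 4 is expected to give about 40 ug/mL, in the range 10 ug/mL to 100 ug/mL.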

Compound 4, half-maximal inhibitory concentration: 35 ug/mL
Compound 4: the middle estimate sits 1.1-fold (0.06 log units) above what was measured; low and high end bracket the measured number.
By their numbers in this assay, from the lowest: compounds 1, 4 and 3 (each within the scatter of the next). At a limit, above all of these: compound 2.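

Among the compounds shown here, until this result, the position had carried only halogens, and the hydroxy group is the first substituent there that counts as a hydrogen-bond donor. In this assay, the step of a 1.8-fold lower number from compound 3 to compound 4 (0.26 log units; within the scatter) and the step of a 1.1-fold higher number from compound 1 to compound 4 (0.03 log units; within the scatter) show that this change leaves the reading within the scatter, so fluoro, chloro and hydroxy on this aromatic carbon cannot be told apart in this assay. Nothing at hand bears on why these three groups read alike.

The compounds shown leave open whether an amine, a carboxylic acid or a longer chain on this carbon would give a step beyond the scatter. Among the steps shown at this position, none yet lies beyond it, so how much this position matters in the series remains unsettled.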